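The source may report more compounds than this note shows. Statements on the series, on what has been measured and on what is new or still open speak of the compounds shown alone.

Measured so far:
compound 1 `CC(C)CCn1ccc(-c2ccc(OC3CCCC3)c(Cl)c2)c(C#N)c1=O` gives 199% in a functional assay on CHO cells for positive allosteric modulation of metabotropic glutamate receptor 2 (Homo sapiens), read by scintillation counting and GTPgammaS binding, with a stated time of 30 min; on this read-out higher numbers stand for larger maximal responses and lower numbers for smaller maximal responses;
compound 2 `CC(C)CCn1ccc(-c2ccc(Oc3ccccc3)cc2)c(C#N)c1=O` gives 188%;
compound 3 `CCCCn1ccc(-c2ccc(Oc3cccnc3C)cc2)c(C#N)c1=O` gives 228%.

Compound 2 stands lowest of these three numbers. Compound 1 sits higher, beyond the scatter, and compound 3 higher still, also beyond the scatter.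

Compound 4 `Cc1ccc(Oc2ccc(-c3ccn(CCC(C)C)c(=O)c3C#N)cc2)c(C)n1` comes from compound 2 by one change: 2,6-dimethylpyridin-3-yl in place of phenyl on an oxygen on an aromatic ring. Among the compounds with values here, no measured pair shows this exact exchange, so the expectation rests on the spread of the three numbers. Since compound 3 reaches 228% with a related ether, a modest rise beyond the scatter is expected from compound 2 to compound 4, about a number 22 percentage points higher from compound 2 to compound 4 (beyond the scatter). Compound 4 is therefore estimated at 210%, within a range from 185% to 240%.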

Compound 4, largest response reached (Emax), in percent of the reference or control that the assay uses: 246%
Beside the measured number, compound 4's estimate is 36 percentage points below it; measured number above the stated range.
By their numbers in this assay, from the lowest: compound 2; then compound 1; then compound 3; then compound 4.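

Replacing the phenyl on the oxygen with 2,6-dimethylpyridin-3-yl gives a number 58 percentage points higher from compound 2 to compound 4 (beyond the scatter) in this assay. Within the data shown here, this is the first pair here that differs in one place only, and it shows that the group on this oxygen can strongly change the maximal response. No measurement shown explains this step.

On these data alone, it remains open whether the ring nitrogen, the two methyl groups or both together carry the step. A plain pyridin-3-yl and a 2,6-dimethylphenyl on the same oxygen would separate these parts.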